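Dodecyl cyanoacrylates: from furan to indole in mice

The compounds below may be only part of what the source reports. "The series", "measured", "known", "first", "only" and "open" are said of these compounds alone.

Of the compounds shown here, three have been measured. Compound 1 `CCCCCCCCCCCCOC(=O)/C(C#N)=C/c1ccc(O)c(O)c1` gives 45.2% in a functional assay on the whole organism (strain CD1) for inhibition, with Mus musculus as the target, with stated times of 15 min and 20 min, at a dose of 10 mg/kg by the subcutaneous route; on this read-out lower numbers stand for less inhibition and higher numbers for more inhibition at the one dose given (going by the name of the read-out). Compound 2 `N#C/C(=C\c1ccsc1)C(=O)O` gives 1.8% in this assay. Compound 3 `CCCCCCCCCCCCOC(=O)/C(C#N)=C/c1ccoc1` gives 53.8% in this assay, the highest of the three numbers; its nearest neighbour is compound 1, whose value sits within the scatter of it, while compound 2 lies beyond the scatter and shows far less inhibition. Compound 2 differs from compound 3 in more than one place, so only the two values themselves can be compared.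

Compound 4 `CCCCCCCCCCCCOC(=O)/C(C#N)=C/c1cc2ccccc2[nH]1` is not yet measured. It differs from compound 3 by 1H-indol-2-yl in place of furan-3-yl on a double-bonded chain carbon bound to a double-bonded chain carbon. Going by the values given here, the only step that bears on this position is the ring exchange a number 8.6 percentage points higher from compound 1 to compound 3 (within the scatter), which stayed within the scatter. Nothing shown separates one aromatic ring at this place from another, so the step of a number 3.8 percentage points lower from compound 3 to compound 4 (within the scatter) is expected to stay within the scatter as well. Compound 4 is therefore estimated to give 50%, with a range from 25% to 75%.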

Compound 4, a percentage reported as inhibition, in the whole organism at one dose (the size of the read-out at that dose, not a potency): 54.1%
Compound 4: middle estimate off by 4.1 percentage points, on the low side, and the stated range covers the measured number.
By their numbers in this assay, from the lowest: compound 2; then compounds 1, 3 and 4 (each within the scatter of the next).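

In this assay, 1H-indol-2-yl in place of furan-3-yl gives a number 0.3 percentage points higher from compound 3 to compound 4 (within the scatter), and in place of 3,4-dihydroxyphenyl it gives a number 8.9 percentage points higher from compound 1 to compound 4 (within the scatter). The earlier compounds shown here offered a single exchange at this place, on a double-bonded chain carbon bound to a double-bonded chain carbon; now three aromatic groups there lie within the scatter of one another. That holds even though the entering group brings a second aromatic ring and a hydrogen-bond donor where furan-3-yl has an acceptor. No measurement shown accounts for this outcome.

Going by these compounds, whether a group without an aromatic ring, such as an amine, would keep this level of inhibition at this place remains open. So does the effect of a shorter chain in place of the dodecyl chain with any one of these rings held constant.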